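The source may hold more compounds than are shown below. What is called first, only, known or untested is meant among the compounds shown, and "the series" means these compounds.

Measured so far in a functional assay on SK-MEL-28 cells (Homo sapiens) for inhibition, read by sulforhodamine B assay, with a stated time of 48 h; a higher number here means that more compound is tolerated, a lower number that less compound is tolerated:
compound 1, `COc1cc(-c2nn(-c3cccc(NC(=O)c4cccc(C(F)(F)F)c4)c3)cc2-c2ccncc2)ccc1Cl`: > 50000 nM, a limit of the assay
compound 2, `O=C(Nc1cccc(-n2cc(-c3ccncc3)c(-c3ccc(Cl)c(O)c3)n2)c1)Nc1cc(C(F)(F)F)cc(C(F)(F)F)c1`: 3090 nM
compound 3, `COc1cc(-c2nn(-c3cccc(NC(=O)c4ccccc4)c3)cc2-c2ccncc2)ccc1Cl`: > 100000 nM, a limit of the assay

Within the data shown here, compound 2 thus stands as the only compound with a real number; the other two sit at limits. Compound 4, `O=C(Nc1cccc(-n2cc(-c3ccncc3)c(-c3ccc(Cl)c(O)c3)n2)c1)Nc1cccc(C(F)(F)F)c1`, differs from compound 2 by hydrogen in place of trifluoromethyl on an aromatic carbon. Among the measured compounds shown here, the one measured step of this kind, a step that the two limits leave unreadable from compound 1 to compound 3, is unreadable, because both ends rest at the limit of > 50000 nM in this assay, at which 1 of the 3 values shown sits, and (the limit of > 100000 nM in this assay, at which 1 of the 3 values shown sits). There is therefore no measured guide to the size of this change. For compound 4 the expected step is small, a 1.6-fold higher number from compound 2 to compound 4 (0.21 log units; within the scatter), toward a slightly less tolerated compound. The estimate for compound 4 in this assay is 5000 nM, with a range from 1500 nM to 20000 nM.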

Compound 4, concentration lethal to 50% of the cells: > 32500 nM
Compound 4: no number, only a limit; the forecaster's own chance of this, stated with the estimate: 15%; at least 6.5-fold (0.81 log units) between middle value and limit.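

In this assay, replacing this one trifluoromethyl group with hydrogen, while the ring keeps its other trifluoromethyl group, brings an at least 10-fold higher number from compound 2 to compound 4 (1.02 log units; beyond the scatter). Among these compounds, the same change between compound 1 and compound 3 gave no readable size, so this is the first sign that the change can cost a large step on this ring. Compound 4 gives > 32500 nM, which is a limit of the assay.

Still open, going by these compounds, is whether a different group at this position, such as an amine or a nitrile, would keep the number close to that of compound 2.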